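Trimming the Branch Point Toward an Unsubstituted Chain

The source may hold more compounds than are shown below. What is called first, only, known or untested is meant among the compounds shown, and "the series" means these compounds.

Compound 3 `CCCC(CCc1nnn[nH]1)Cc1cccc(OCc2ccc3ccccc3n2)c1` stands at the lowest of the three numbers in an assay on membranes from lung (Cavia porcellus) for binding affinity to cysteinyl leukotriene receptor (Homo sapiens) (on this read-out higher numbers stand for weaker inhibition and lower numbers for stronger inhibition), giving 11 nM, though its gaps to both other compounds lie within the scatter. Compound 2 `c1ccc(C(CCc2nnn[nH]2)Cc2cccc(OCc3ccc4ccccc4n3)c2)cc1` gives 14 nM in this assay, and compound 1 `CC(CCc1cccc(OCc2ccc3ccccc3n2)c1)Cc1nnn[nH]1` gives 17 nM. For the measured compounds named here, the only measured step touching the same position is a 1.3-fold lower number from compound 2 to compound 3 (0.10 log units; within the scatter). Compound 4 `c1cc(CCCCc2nnn[nH]2)cc(OCc2ccc3ccccc3n2)c1` carries hydrogen in place of propyl on a saturated chain carbon bound to two saturated chain carbons. Going by the values given here, no measured step removes the branch substituent altogether, so the expectation rests on the finding that compound 1 at 17 nM, compound 2 at 14 nM and compound 3 at 11 nM all sit within the scatter of one another; a small shift toward a higher number, or none beyond the scatter, is therefore expected. Compound 4 is estimated at 20 nM in this assay, with a range of 7 nM to 60 nM. This amounts to an expected step of a 1.8-fold higher number from compound 3 to compound 4 (0.26 log units; within the scatter).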

Compound 4, inhibition constant: 20 nM
Compound 4: the middle estimate sits on the measured number at the digits printed, within the range that was stated.
By their numbers in this assay, from the lowest: compounds 3, 2, 1 and 4 (each within the scatter of the next).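

In this assay, replacing the substituent on this saturated chain carbon with hydrogen stays within the scatter whichever group leaves: propyl (a 1.8-fold higher number from compound 3 to compound 4 (0.26 log units; within the scatter)), phenyl (a 1.4-fold higher number from compound 2 to compound 4 (0.15 log units; within the scatter)) or methyl (a 1.2-fold higher number from compound 1 to compound 4 (0.07 log units; within the scatter)). Hydrogen, methyl, propyl and phenyl therefore cannot be told apart at this position on this read-out, and none of the three groups is shown to change the number beyond the scatter. No evidence is available that bears on this result. As far as these compounds go, whether an amine, a carboxylic acid or a longer chain on this carbon would move the number beyond the scatter remains open.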